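Chain-end carboxylic acid in place of bromine on compound 2

The compounds below may be only part of what the source reports. "The series", "measured", "known", "first", "only" and "open" are said of these compounds alone.

Compound 2 `O=c1c(-c2ccc(O)cc2)coc2cc(OCCCCCCBr)ccc12` stands highest of the three numbers in a functional assay on mitochondria (Cricetulus griseus) for inhibition of Monoamine oxidase (Homo sapiens), tested at 0.3 uM (a lower number here means a weaker effect, a higher number a stronger effect of the compound at the concentration tested), with compound 2 giving 47.2%. Compound 3 `O=c1c(-c2ccc(O)cc2)coc2cc(OCCC3OCCCO3)ccc12` gives 41% in this assay, and the step of a number 6.2 percentage points lower from compound 2 to compound 3 (within the scatter) lies within the scatter, so an exchange at the far end of the ether chain left the read-out essentially unchanged. Among the measured compounds shown here, compound 1 `O=c1c(-c2ccc(O)cc2)coc2cc(CC3OC(CO)C(O)C(O)C3O)ccc12`, which carries no ether chain, gives 0% in this assay; no single-place step links it to compound 2, and the two values only show that the chain-bearing compound 2 sits far above it.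

Compound 4 `O=C(O)CCCCCCCCCOc1ccc2c(=O)c(-c3ccc(O)cc3)coc2c1` differs from compound 2 in one place: 3-carboxypropyl in place of bromo on a saturated chain carbon, six bonds along the chain from an oxygen on an aromatic ring. For the measured compounds named here, the only measured step that bears on this change is the chain-end exchange from compound 2 to compound 3, which stayed within the scatter. The entering group here is longer and brings a hydrogen-bond donor and acceptor, so a somewhat larger move cannot be ruled out, with a drop more likely than a rise. Compound 4 is therefore expected to give 32% in this assay, between 8% and 55%. This expectation means a step of a number 15.2 percentage points lower from compound 2 to compound 4 (beyond the scatter), estimated to lie near the edge of the scatter.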

Compound 4, a percentage reported as inhibition, at one concentration (the size of the read-out at that concentration, not a potency): 74.4%
Compound 4: the middle estimate sits 42.4 percentage points below what was measured, and the stated range ends below it.
By their numbers in this assay, from the lowest: compound 1; then compounds 3 and 2 (each within the scatter of the next); then compound 4.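

At the far end of the ether chain, the read-out in this assay does respond to the group carried there: a number 27.2 percentage points higher from compound 2 to compound 4 (beyond the scatter), with 3-carboxypropyl in place of bromo, so the earlier step within the scatter did not mean that this position tolerates any exchange without effect. The second step, a number 33.4 percentage points higher from compound 3 to compound 4 (beyond the scatter), is larger and shows that the open chain ending in the carboxylic acid also stands clear of the chain ending in the six-membered non-aromatic ring. No measurement at hand accounts for this gain.

The compounds shown change chain length and end group together, so the share of each in the higher read-out stays open. A methyl ester or an amine at the end of the same chain, and a carboxylic acid on a shorter chain, would separate the two.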